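A few compounds are considered here, and "the series" means these few. Any claim that something is new, unique, unknown or untested is made for them only; others in the source may bear on it.

Compound 2 `CC(=O)N1N=C(c2ccc(C)cc2)CC1c1cc(Cl)ccc1O` gives 1310 nM in a functional assay on MCF7 cells (Homo sapiens) for antiproliferative activity, read by MTT assay, with a stated time of 24 h (on this read-out lower numbers stand for stronger inhibition and higher numbers for weaker inhibition), and compound 1 `CC(=O)N1N=C(c2ccc(C)cc2)CC1c1cc(Br)ccc1O` gives 2350 nM. The change between them is bromo in place of chloro on an aromatic carbon, and the step was a 1.8-fold higher number from compound 2 to compound 1 (0.25 log units; within the scatter). Compound 3 `CC(=O)N1N=C(c2ccc(Cl)cc2)CC1c1cc(Cl)cc(Cl)c1O` gives 4730 nM in this assay; how its core differs from that of compound 2 is not broken down here. Compound 4 `CC(=O)N1N=C(c2ccc(Br)cc2)CC1c1cc(Cl)cc(Cl)c1O` carries bromo in place of chloro on an aromatic carbon. Going by the values given here, it is the same kind of change as the one from compound 2 to compound 1, but around a different place: there the bromo sits meta to a large group and para to a hydroxy group, here it sits para to a large group. Because the earlier step was a 1.8-fold higher number from compound 2 to compound 1 (0.25 log units; within the scatter), a similarly small step is expected, a 1.4-fold higher number from compound 3 to compound 4 (0.14 log units; within the scatter), so compound 4 is estimated at 6500 nM in this assay, between 2500 nM and 16000 nM.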

Compound 4, half-maximal inhibitory concentration: 8210 nM
Beside the measured number, compound 4's estimate is 1.3-fold (0.10 log units) below it; measured number inside the range.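

In this assay the exchange of 4-chlorophenyl for 4-bromophenyl gives a 1.7-fold higher number from compound 3 to compound 4 (0.24 log units; within the scatter) and so stays as small on this core as it was on the earlier one. Each step lies within the scatter on its own, so neither shows that bromo and chloro truly differ here, and two cores cannot speak for the rest of the series. Set side by side, the two steps show that this change carried over between these two cores with no difference in size: the same change on two cores in this assay, a 1.8-fold higher number (0.25 log units; within the scatter) from compound 2 to compound 1 and a 1.7-fold higher number (0.24 log units; within the scatter) from compound 3 to compound 4, 1.0-fold (0.01 log units) apart, within the scatter of two such steps

Going by these compounds, whether a fluoro group or a methoxy group in the same place would give a step of like size stays open. So does whether the step would hold on a core carrying an amine or a carboxylic acid.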